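Varying the group on the aromatic nitrogen: compound 4

The compounds below may be only part of what the source reports. "The series", "measured", "known", "first", "only" and "open" are said of these compounds alone.

Compound 1 `CCOC(=O)c1ccc(-c2nn(C)c3ccccc23)cc1` gives 270 nM in a functional assay on cells (Platelet, Homo sapiens) for inhibition; a higher number here means a weaker inhibitor, a lower number a stronger inhibitor. Compound 2 `CCOC(=O)c1ccc(-c2nn(Cc3ccccc3Cl)c3ccccc23)cc1` gives 230 nM in this assay. Compound 3 `CCOC(=O)c1ccc(-c2nn(Cc3cccc(F)c3)c3ccccc23)cc1` gives 270 nM in this assay.

Compound 3 stands level with compound 1, the pair together giving the highest numbers of the three; its gap to compound 2, a 1.2-fold higher number from compound 2 to compound 3 (0.07 log units; within the scatter), is within the scatter, so no order among the three is established.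

Compound 4 `CCOC(=O)c1ccc(-c2nn(Cc3ccccc3OC)c3ccccc23)cc1` differs from compound 3 by 2-methoxyphenyl in place of 3-fluorophenyl on a saturated chain carbon bound to an aromatic nitrogen. Within the data shown here, three measured steps bear on this position. Adding 3-fluorophenyl at this carbon, no change at the digits printed from compound 1 to compound 3 (within the scatter), adding 2-chlorophenyl there, a 1.2-fold lower number from compound 1 to compound 2 (0.07 log units; within the scatter), and swapping one for the other, a 1.2-fold higher number from compound 2 to compound 3 (0.07 log units; within the scatter), all stay within the scatter. Among the measured compounds shown here, the series so far shows this assay indifferent to what sits on this carbon, so for compound 4 a step of no more than the scatter is expected in either direction, a 1.1-fold lower number from compound 3 to compound 4 (0.03 log units; within the scatter).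

Compound 4 is therefore estimated at 250 nM in this assay, with a range of 120 nM to 520 nM.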

Compound 4, half-maximal inhibitory concentration: 470 nM
Beside the measured number, compound 4's estimate is 1.9-fold (0.27 log units) below it; the range from low to high includes it.
By their numbers in this assay, from the lowest: compounds 2, 1, 3 and 4 (each within the scatter of the next, the first and the last beyond it).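

In this assay the exchange of chloro for methoxy on an aromatic carbon gives the first step at this position to pass the scatter, a 2.0-fold higher number from compound 2 to compound 4 (0.31 log units; beyond the scatter), though only modestly, so the group on this carbon is no longer shown to be without any effect. The other two steps, a 1.7-fold higher number from compound 3 to compound 4 (0.24 log units; within the scatter) and a 1.7-fold higher number from compound 1 to compound 4 (0.24 log units; within the scatter), stay within the scatter, so 2-methoxyphenyl is separated neither from 3-fluorophenyl nor from hydrogen at this carbon. No evidence at hand accounts for the gap between the chloro and methoxy groups.

Still open, going by these compounds, is whether a carboxylic acid or an amine on this phenyl ring, or a longer chain in place of the benzyl group, would move the number clearly away from that of compound 1. Also open, on these data alone, is how a nitrile on the same aromatic carbon would compare with chloro and methoxy.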